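The compounds below may be only part of what the source reports. "The series", "measured", "known", "first", "only" and "open" are said of these compounds alone.

Measured so far:
compound 1 `CC(Sc1nc2c(cnn2C)c(=O)n1-c1ccc(CO)cc1)c1ccccc1`; in an assay on isolated protein for inhibition of Retinaldehyde dehydrogenase 3 (Homo sapiens) (on this read-out lower numbers stand for stronger inhibition and higher numbers for weaker inhibition), compound 1 gives 1000 nM
compound 2 `C[C@@H](Sc1nc2c(cnn2C)c(=O)n1-c1ccccc1)c1ccccc1`; in this assay compound 2 gives 34 nM

Compound 2 holds the lower of the two numbers in this assay; compound 1 stands well apart from it, beyond the scatter. The two differ in more than one place, so nothing is attributed to either difference on its own.

Compound 3 `CC(Sc1nc2c(cnn2C)c(=O)n1-c1ccccc1)c1cccc(O)c1` is not yet measured. It follows from compound 2 by a group of 9 heavy atoms (8 carbon, 1 oxygen; one six-membered aromatic ring of carbon only) in place of a group of 8 heavy atoms (8 carbon; one six-membered aromatic ring of carbon only), on a sulfur. With this change the defined stereocentre of compound 2 is no longer specified in compound 3.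

Going by the values given here, no single-point step is available to calibrate this. A step beyond the scatter is expected, towards a higher number, given that compound 1, also without a defined stereocentre, gives 1000 nM in this assay. Compound 3 is therefore estimated at 150 nM in this assay, range 40 nM to 600 nM, an expected step of a 4.4-fold higher number from compound 2 to compound 3 (0.64 log units; beyond the scatter).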

Compound 3, half-maximal inhibitory concentration: 91 nM
Compound 3: the middle estimate sits 1.6-fold (0.22 log units) above what was measured; low and high end bracket the measured number.
By their numbers in this assay, from the lowest: compound 2; then compound 3; then compound 1.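

Working note on the group on the sulfur: in this assay, replacing 1-phenylethyl with the group that carries one oxygen, one hydrogen-bond donor and one hydrogen-bond acceptor gives a 2.7-fold higher number from compound 2 to compound 3 (0.43 log units; beyond the scatter), a first reading at this position that the earlier compounds could not supply. The same step also takes away the defined stereocentre of compound 2, so it cannot be divided between the added oxygen and the stereocentre, and it sets no separate size for either. No measurement at hand bears on the reason for this step.

Open, on these data alone, is what the stereocentre contributes on its own, and whether a methoxy group, an amine or a carboxylic acid in place of the oxygen-bearing substituent on the aromatic ring of this group would give a number close to that of compound 3. Also open, as far as these compounds go, is how changes elsewhere on the shared core read out on their own, since compound 1 differs from compound 2 in more than one place.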